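Bromo for Fluoro, Repeated on a Second Core

This account rests on a few compounds, and the source may have more. Where it says the series, first, only, none or still open, it means among the compounds named here.

Three compounds have been measured in a functional assay on OVCAR-8 cells (Homo sapiens); on this read-out lower numbers stand for stronger inhibition of growth and higher numbers for weaker inhibition of growth:
compound 1 `O=S(=O)(/C=C/c1ccc(F)cc1)Cc1ccc(Nc2ncnc3ccccc23)cc1` gives 2000 nM;
compound 2 `O=S(=O)(/C=C/c1ccc(Br)cc1)Cc1ccc(Nc2ncnc3ccccc23)cc1` gives 38000 nM;
compound 3 `COc1cc2ncnc(Nc3ccc(CS(=O)(=O)/C=C/c4ccc(F)cc4)cc3)c2cc1OC` gives > 100000 nM, which is a limit of the assay rather than a number.

Compound 1 and compound 2 share a core and differ only by bromo in place of fluoro on an aromatic carbon. That change cost potency: a 19-fold higher number from compound 1 to compound 2 (1.28 log units; beyond the scatter). Compound 3 carries a different core; how the two cores differ is not broken down here. Compound 4 `COc1cc2ncnc(Nc3ccc(CS(=O)(=O)/C=C/c4ccc(Br)cc4)cc3)c2cc1OC` is not yet measured and stands to compound 3 as compound 2 stands to compound 1, by bromo in place of fluoro on an aromatic carbon, the same change at the same place. Because compound 3 already sits at the limit of > 100000 nM in this assay, at which 1 of the 3 values shown sits, compound 4 is expected to remain at or beyond that limit, with an expected step that the limit leaves unreadable from compound 3 to compound 4. The estimate for compound 4 is 300000 nM.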

Compound 4, concentration for 50% growth inhibition: 6000 nM
For compound 4 the middle estimate is 50-fold (1.70 log units) above the measured one; the whole stated range lies above it.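

Bromo in place of fluoro gave an at least 16-fold lower number from compound 3 to compound 4 (1.22 log units; beyond the scatter) in this assay. The step measured on one core therefore did not predict the step on the other, and the direction itself reversed: the same change on two cores in this assay, a 19-fold higher number (1.28 log units; beyond the scatter) from compound 1 to compound 2 and an at least 16-fold lower number (1.22 log units; beyond the scatter) from compound 3 to compound 4, at least 310-fold (2.50 log units) apart, beyond the scatter of two such steps

These two pairs show that the outcome of this change depends on the core, but not why, and compound 3 gives > 100000 nM, which is only a limit of the assay and not a number.

Going by these compounds, it remains open how a chloro group or an amine in the same place would behave on each core. On these data alone, it is also open which part of the difference between the two cores matters.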